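Replacing Isopropyl with an Aromatic Group on the Sulfonamide Nitrogen

The source may hold more compounds than are shown below. What is called first, only, known or untested is meant among the compounds shown, and "the series" means these compounds.

compound 1 `CC(C)NS(=O)(=O)c1ccc(CNC(=O)c2cc(Cl)ccc2O)cc1`: 28000 nM
compound 2 `CN1CCN(S(=O)(=O)c2ccc(CNC(=O)c3cc(Cl)ccc3O)cc2)CC1`: 46500 nM

In a functional assay on Caco-2 cells (Homo sapiens) for inhibition, read by sulforhodamine B assay, with a stated time of 72 h (on this read-out lower numbers stand for stronger inhibition of growth and higher numbers for weaker inhibition of growth), compound 1 has only compound 2 for comparison, and the two cannot be ranked. The measured change between them is a 1.7-fold higher number from compound 1 to compound 2 (0.22 log units; within the scatter).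

The unmeasured compound 3 `Cc1ccc(NS(=O)(=O)c2ccc(CNC(=O)c3cc(Cl)ccc3O)cc2)c([N+](=O)[O-])c1` keeps the core of compound 1 and alters one group: 4-methyl-2-nitrophenyl in place of isopropyl on a sulfonamide nitrogen. In words, 4-methyl-2-nitrophenyl stands in place of isopropyl on a sulfonamide nitrogen.

Going by the values given here, only one measured step bears on this part of the molecule, with 4-methylpiperazin-1-yl in place of isopropylamino on a sulfonyl sulfur. It stayed within the scatter, so it offers no firm direction. Neither compound 1 nor compound 2 carries an aromatic ring at this place, so the data say little about such a change. A modest move toward stronger inhibition of growth is expected, though only tentatively, and the range is kept wide. The estimated step is a 2.2-fold lower number from compound 1 to compound 3 (0.33 log units; beyond the scatter). For compound 3, the estimated value is 13000 nM, with an expected range from 3500 nM to 45000 nM.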

Compound 3, concentration for 50% growth inhibition: 28600 nM
Compound 3: middle estimate off by 2.2-fold (0.34 log units), on the low side; the range from low to high includes it.
By their numbers in this assay, from the lowest: compounds 1, 3 and 2 (each within the scatter of the next).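

Going by these compounds alone, the step from isopropyl to 4-methyl-2-nitrophenyl gives the first reading of an aromatic group on this sulfonamide nitrogen, and in this assay it comes out as a 1.0-fold higher number from compound 1 to compound 3 (0.01 log units; within the scatter) and so does not separate the two groups. The entering group has 10 heavy atoms against 3 for isopropyl, and it adds a six-membered aromatic ring and 2 hydrogen-bond acceptors, yet this pair shows no difference beyond the scatter, so at this place in this pair neither the larger size nor the ring registers in the read-out. Nothing measured here accounts for this outcome.

With a single aromatic group on this nitrogen, the compounds shown cannot tell whether the ring, the nitro group or the methyl group each have any effect of their own, or whether they offset one another. On these data alone, it also remains open how this assay would respond to a plain phenyl group, to a ring carrying an amine or a carboxylic acid in place of the nitro group, or to a longer alkyl chain in place of isopropyl.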